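From 3-methylbenzyl to 3-nitrobenzyl: an expected step

A few compounds are considered here, and "the series" means these few. Any claim that something is new, unique, unknown or untested is made for them only; others in the source may bear on it.

In a functional assay on KB cells (Homo sapiens) for inhibition (a lower number here means a stronger inhibitor, a higher number a weaker inhibitor), compound 1 `N#CCSc1nc2cc(Cl)c(Cl)cc2n1C1O[C@H](CO)[C@@H](O)[C@H]1O` reads > 100000 nM, which is a limit of the assay and not a number. Among the measured compounds shown here, compound 2 `Cc1cccc(CSc2nc3cc(Cl)c(Cl)cc3n2C2O[C@H](CO)[C@@H](O)[C@H]2O)c1` gives 30000 nM, the only actual number available in this assay. Compound 3 `O=[N+]([O-])c1cccc(CSc2nc3cc(Cl)c(Cl)cc3n2C2O[C@H](CO)[C@@H](O)[C@H]2O)c1` differs from it in one place: nitro in place of methyl on an aromatic carbon, with nitro in place of methyl on an aromatic carbon, meta to a large group.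

For the measured compounds named here, only one measured step bears on this change. Placing 3-methylphenyl in place of cyano on a saturated chain carbon bound to a sulfur gave an at least 3.3-fold lower number from compound 1 to compound 2 (0.52 log units; beyond the scatter), and its size is bounded by the limit of > 100000 nM in this assay, at which 1 of the 2 values shown sits. That step altered the chain group and not a substituent on the aromatic ring, so it offers only a loose guide. No change beyond the scatter is expected in this assay, and the expected step is a 1.2-fold higher number from compound 2 to compound 3 (0.07 log units; within the scatter). For compound 3 the estimate is 35000 nM, with an expected range of 11000 nM to 100000 nM.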

Compound 3, half-maximal inhibitory concentration: 25000 nM
Compound 3: middle estimate off by 1.4-fold (0.15 log units), on the high side; low and high end bracket the measured number.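

In this assay, nitro in place of methyl on an aromatic carbon gave a 1.2-fold lower number from compound 2 to compound 3 (0.08 log units; within the scatter), so this first change on the ring itself does not separate the 3-nitrobenzyl compound from the 3-methylbenzyl compound. With 3-nitrophenyl in place of cyano, the change on the saturated chain carbon bound to the sulfur gave an at least 4.0-fold lower number from compound 1 to compound 3 (0.60 log units; beyond the scatter), so the step away from the cyano compound now holds with either ring substituent. The value of compound 1 is a limit of the assay, which leaves the full size of that step open: the limit of > 100000 nM in this assay, at which 1 of the 3 values shown sits.

On these data alone, whether an amine or a carboxylic acid on this aromatic carbon would depart from compound 2 and compound 3 remains open. So does the effect of a longer chain on the sulfur.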